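Furan Ester of an Adenine Hydroxypropanoate: Cytotoxicity Outlook

The source may report more compounds than this note shows. Statements on the series, on what has been measured and on what is new or still open speak of the compounds shown alone.

Compound 3 `CC(C)CCOC(=O)C(O)Cn1cnc2c(N)ncnc21` gives 400 ug/mL in a functional assay on PRK cells (Oryctolagus cuniculus) for cytotoxicity (on this read-out lower numbers stand for higher toxicity in this test and higher numbers for lower toxicity in this test), the highest of the two plain numbers shown. Compound 1 `CCCCCCCCOC(=O)C(O)Cn1cnc2c(N)ncnc21` gives 100 ug/mL in this assay, and the step of a 4.0-fold higher number from compound 1 to compound 3 (0.60 log units; beyond the scatter) is modest. Compound 2 `COC(=O)C(O)Cn1cnc2c(N)ncnc21` reaches only a limit of this assay, > 400 ug/mL, which is the limit of > 400 ug/mL in this assay, at which 1 of the 3 values shown sits. The step of an at least 4.0-fold higher number from compound 1 to compound 2 (0.60 log units; beyond the scatter) points the same way, while a number no higher from compound 2 to compound 3 (the limit leaves the size open) leaves its size open. Compound 4 `Nc1ncnc2c1ncn2CC(O)C(=O)OCc1ccco1` differs from compound 3 by furan-2-yl in place of isobutyl on a saturated chain carbon bound to an oxygen next to a carbonyl group. The ester side chain stays comparable in size to that of compound 3, so the expected step of no change at the digits printed from compound 3 to compound 4 (within the scatter) is none beyond the scatter. Compound 4 is therefore estimated at 400 ug/mL in this assay, between 200 ug/mL and 800 ug/mL.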

Compound 4, minimum cytotoxic concentration: 40 ug/mL
The estimate for compound 4 lay 10-fold (1.00 log units) above the measured number, and the stated range ends above it.
By their numbers in this assay, from the lowest: compound 4; then compound 1; then compound 3.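

In this assay the change to furan-2-yl at this place gives a 10-fold lower number from compound 3 to compound 4 (1.00 log units; beyond the scatter) and also a 2.5-fold lower number from compound 1 to compound 4 (0.40 log units; beyond the scatter), so chain length alone does not set the number at this ester. A limit of the assay stands at one end of an at least 10-fold lower number from compound 2 to compound 4 (1.00 log units; beyond the scatter), so only a minimum size can be read there. Nothing measured here accounts for the drop.

On these data alone, whether it follows the aromatic ring or the ring oxygen stays open. A benzyl ester and a tetrahydrofuran-2-ylmethyl ester would separate the two.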